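The source may hold more compounds than are shown below. What is called first, only, known or untested is meant among the compounds shown, and "the series" means these compounds.

Measured compounds
- compound 1, `COc1cc(OC)c2c(=O)cc(-c3ccc(OCCCN(C)C)cc3)oc2c1`: 86%
- compound 2, `COc1cc(OC)c2c(=O)cc(-c3ccc(OCCCN)cc3)oc2c1`: "not determined" (no result reported) in a functional assay (Homo sapiens) for antiproliferative activity, read by resazurin assay, with a stated time of 48 h, tested at 20 uM; on this read-out lower numbers stand for a weaker effect and higher numbers for a stronger effect at the one concentration tested

Among the measured compounds shown here, compound 1 is the only member of the series with a number in this assay, where it gives 86%. For the measured compounds named here, compound 2 carries a different chain on the same oxygen; for compound 2 this assay returned "not determined" (no result reported), so compound 2 stands without a number and no step from compound 1 to compound 2 can be sized.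

Compound 3 is `COc1cc(OC)c2c(=O)cc(-c3ccc(OCC(O)CN4CCCC4)cc3)oc2c1`. Its difference from compound 2 is 1-hydroxy-2-(pyrrolidin-1-yl)ethyl in place of 2-aminoethyl on a saturated chain carbon bound to an oxygen on an aromatic ring.

Going by the values given here, no measured pair shows what a change of this kind does in this assay. Compound 3 shares with compound 1 a tertiary amine at the end of the propoxy chain and adds a hydroxy group, and compound 1 gives 86%; on that single point, compound 3 is expected to land in the same high region, with no direction beyond the scatter that can be stated from the data. For compound 3 the estimated value in this assay is 78%, with a range from 55% to 95%.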

Compound 3, a percentage reported as inhibition, at one concentration (the size of the read-out at that concentration, not a potency): 57%
Compound 3: middle estimate off by 21 percentage points, on the high side; low and high end bracket the measured number.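

This position, on a saturated chain carbon bound to an oxygen on an aromatic ring, now has its first sized change. In this assay, 1-hydroxy-2-(pyrrolidin-1-yl)ethyl in place of 2-(dimethylamino)ethyl gives a number 29 percentage points lower from compound 1 to compound 3 (beyond the scatter) and compound 3 still reads 57% at the one concentration tested, so the read-out responds to what the chain carries without falling away altogether. Compound 2 has no number, so the step from compound 2 to compound 3 cannot be read, and nothing measured on these compounds accounts for the size of the step from compound 1.

The change brings in the hydroxy group and the pyrrolidine ring together, so the compounds shown do not assign the lower number to either one. As far as these compounds go, a 2-(pyrrolidin-1-yl)ethyl chain without the hydroxy group and a 1-hydroxy-2-(dimethylamino)ethyl chain would each separate the two parts, and a piperidine or morpholine ring at the end of the chain remains open as well.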